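Benzyl swap on the aminoquinoline side chain: permeability outlook

A few compounds are considered here, and "the series" means these few. Any claim that something is new, unique, unknown or untested is made for them only; others in the source may bear on it.

Compound 3 `COc1ccc(F)cc1CNCCCNc1ccnc2cc(Oc3cccc(N(C)C)c3)ccc12` gives 317 10^-6 cm/s in an ADME assay for permeability, using PAMPA, with a stated time of 30 min, at pH 7.4; a lower number here means that the compound crosses the layer more slowly, a higher number that the compound crosses the layer faster. It is level with compound 2 `COc1cccc(Oc2ccc3c(NCCCNCc4cccc(OC)c4O)ccnc3c2)c1`, which gives 317 10^-6 cm/s, and compound 1 `COc1cccc(CNCCCNc2ccnc3cc(-c4ccc(F)cc4)ccc23)c1O` gives 237 10^-6 cm/s, the gap from compound 3 to compound 1 lying within the scatter. All three measured numbers therefore sit close together.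

Compound 4 `COc1cccc(CNCCCNc2ccnc3cc(Oc4cccc(N(C)C)c4)ccc23)c1O` differs from compound 3 by 2-hydroxy-3-methoxyphenyl in place of 5-fluoro-2-methoxyphenyl on a saturated chain carbon bound to an amine nitrogen. Within the data shown here, no measured step probes this exact exchange. Among the measured compounds shown here, the single measured step, a 1.3-fold higher number from compound 1 to compound 2 (0.13 log units; within the scatter), touches a different place and is within the scatter. Compounds 1 and 2 already carry the 2-hydroxy-3-methoxybenzyl group that enters here, and both give numbers of the same size as compound 3, so nothing in the set suggests a shift in this assay beyond the scatter.

For compound 4 the expectation is a step of a 1.1-fold lower number from compound 3 to compound 4 (0.02 log units; within the scatter) in this assay, that is no movement beyond the scatter. Compound 4 is estimated at 300 10^-6 cm/s, with a range from 180 10^-6 cm/s to 480 10^-6 cm/s.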

Compound 4, apparent permeability: 317 10^-6 cm/s
Estimate against measurement, compound 4: 1.1-fold (0.02 log units) below; the range from low to high includes it.
By their numbers in this assay, from the lowest: compounds 1, 2, 3 and 4 (each within the scatter of the next).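

In this assay the exchange at the saturated chain carbon bound to an amine nitrogen can now be read directly: 2-hydroxy-3-methoxyphenyl in place of 5-fluoro-2-methoxyphenyl stays within the scatter (no change at the digits printed from compound 3 to compound 4 (within the scatter)). Dimethylamino in place of methoxy on an aromatic carbon also stays within the scatter (no change at the digits printed from compound 2 to compound 4 (within the scatter)), as does 3-(dimethylamino)phenoxy in place of 4-fluorophenyl on an aromatic carbon (a 1.3-fold higher number from compound 1 to compound 4 (0.13 log units; within the scatter)). Across these steps, neither the benzyl side nor the aryl side of the series moves the read-out beyond the scatter.

Nothing shown offers a reason for this flat picture. Going by these compounds, it remains open whether a carboxylic acid in place of the 2-hydroxy-3-methoxyphenyl, or a longer chain at the same saturated carbon, would also stay within the scatter in this assay on the shared core.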